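The compounds below may be only part of what the source reports. "The series", "measured", "known", "first", "only" and "open" are said of these compounds alone.

Two compounds of the series have a reading in an ADME assay on the whole organism (Rattus norvegicus, strain Wister-Han) for pharmacokinetics, read by LC-MS, at a dose of 1 mg/kg by the intravenous route; on this read-out higher numbers stand for fast clearance and lower numbers for slow clearance. Compound 1 (`Cc1ccncc1C(=O)N1CC(Oc2cncc(N3C(=O)c4ccc(Cl)cc4C3(C)C)c2)C1`) gives 15.8 mL/min/kg and compound 2 (`CCS(=O)(=O)N1CCC(c2cncc(N3C(=O)c4ccc(Cl)cc4C3(C)C)c2)CC1`) gives 29.7 mL/min/kg. These two values lie within the scatter of each other, so neither stands apart on the numbers available.

Compound 3 (`CC1(C)c2cc(Cl)ccc2C(=O)N1c1cncc(OC2CN(C(=O)c3ncccc3Cl)C2)c1`) keeps the core of compound 1 and differs in one place: 3-chloropyridin-2-yl in place of 4-methylpyridin-3-yl on a carbonyl carbon. In words, 3-chloropyridin-2-yl stands in place of 4-methylpyridin-3-yl on a carbonyl carbon whose other neighbour is an amide-type nitrogen in a ring. Among the compounds with values here, no measured pair shows a change in one place, so the size of this step has no direct precedent in the data.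

The expectation therefore starts from compound 1 at 15.8 mL/min/kg, the closest structure with a reading. In this assay the expected change is small and, if anything, towards faster clearance: a 1.3-fold higher number from compound 1 to compound 3 (0.10 log units; within the scatter), not expected to go beyond the scatter. For compound 3 the estimated clearance is 20 mL/min/kg, with an expected range from 9 mL/min/kg to 42 mL/min/kg.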

Compound 3, clearance: 3.1 mL/min/kg
Estimate against measurement, compound 3: 6.5-fold (0.81 log units) above, and the stated range ends above it.
By their numbers in this assay, from the lowest: compound 3; then compounds 1 and 2 (each within the scatter of the next).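

In this assay, within the data shown here, the group on the carbonyl carbon of the core of compound 1 is the first place where a single change can be read, and it matters: 3-chloropyridin-2-yl in place of 4-methylpyridin-3-yl gives a 5.1-fold lower number from compound 1 to compound 3 (0.71 log units; beyond the scatter) on this read-out, a step beyond the scatter that sets compound 3 apart from compounds 1 and 2, which the earlier values could not separate. The group that leaves and the group that enters have the same count of heavy atoms, the same six-membered aromatic ring with one hetero atom, the same hydrogen-bond donors and acceptors and no net charge, so none of these counted features distinguishes the two groups. No measurement shown here bears on what lies behind the step.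

On these data alone, whether the step goes with the chlorine, with the pyridine attachment or with both stays open, and a 3-methylpyridin-2-yl or 3-fluoropyridin-2-yl group on the same carbonyl carbon would help to separate these. Among these compounds, whether 3-chloropyridin-2-yl brings a step of this size on any other core also stays open, as this single pair is the only reading of the change.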